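The compounds below may be only part of what the source reports. "The series", "measured", "known", "first", "only" and "open" are said of these compounds alone.

Compound 1 `O=c1ccoc2cc(OCc3cn(Cc4ccc(Cl)cc4)nn3)ccc12`: > 100000 nM in a functional assay on SW480 cells (Homo sapiens) for cytotoxicity, read by MTT assay, with a stated time of 48 h (on this read-out higher numbers stand for weaker inhibition and lower numbers for stronger inhibition), a limit of the assay.
Compound 2 `Cc1ccccc1Cn1cc(COc2ccc3c(=O)ccoc3c2)nn1`: > 100000 nM, likewise a limit.
Compound 3 `O=c1ccoc2cc(OCc3cn(Cc4cccc(Cl)c4)nn3)ccc12`: 12900 nM.

Compound 1 thus sits at the limit of > 100000 nM in this assay, at which 2 of the 3 values shown sit, and has no number of its own. Compound 4 `O=c1ccoc2cc(OCc3cn(Cc4cccc([N+](=O)[O-])c4)nn3)ccc12` differs from it by 3-nitrophenyl in place of 4-chlorophenyl on a saturated chain carbon bound to an aromatic nitrogen. The measured steps that bear on this change are an at least 7.7-fold lower number from compound 1 to compound 3 (0.88 log units; beyond the scatter) and an at least 7.7-fold lower number from compound 2 to compound 3 (0.88 log units; beyond the scatter), both at least modest drops in the number. Compound 4 carries a 3-nitrophenyl, and compound 3, which carries a 3-chlorophenyl, gives 12900 nM in this assay. Compound 4 is therefore expected to show a step of an at least 5.0-fold lower number from compound 1 to compound 4 (0.69 log units; beyond the scatter), leaving the limit behind. The estimate for compound 4 is 20000 nM, with a range from 7000 nM to 90000 nM.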

Compound 4, half-maximal inhibitory concentration: > 100000 nM
Compound 4: no number, only a limit (the forecaster's own chance of this, stated with the estimate: 30%); at least 5.0-fold (0.69 log units) between middle value and limit.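

In this assay, nitro in place of chloro on an aromatic carbon gives an at least 7.7-fold higher number from compound 3 to compound 4 (0.88 log units; beyond the scatter), so the drop in the number seen with 3-chlorophenyl does not carry over to 3-nitrophenyl. The steps from compound 1 and from compound 2 to compound 4 cannot be read, as all three values are limits. Compound 3 alone has a number of its own here, and the rest share one limit: the limit of > 100000 nM in this assay, at which 3 of the 4 values shown sit.

Going by these compounds, whether a 3-bromophenyl, 3-methylphenyl or 3-aminophenyl on the saturated chain carbon would also give a measurable number remains open. On these data alone, how far compound 1, compound 2 and compound 4 lie beyond their limits also remains open.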